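A few compounds are considered here, and "the series" means these few. Any claim that something is new, unique, unknown or untested is made for them only; others in the source may bear on it.

Of the compounds shown here, three have been measured in a functional assay on KB cells (Homo sapiens) for cytotoxicity, read by MTT assay, with a stated time of 72 h; a higher number here means a weaker inhibitor, a lower number a stronger inhibitor. Compound 1 `COc1cc2ncnc(NNC(=S)NC(=O)c3ccc(F)cc3)c2cc1OC` gives 4530 nM. Compound 3 `COc1cc2ncnc(NNC(=S)NC(=O)c3ccccc3F)c2cc1OC` carries a 2-fluorophenyl in place of the 4-fluorophenyl on the carbonyl carbon and gives 4070 nM; the step of a 1.1-fold lower number from compound 1 to compound 3 (0.05 log units; within the scatter) lies within the scatter. Compound 2 `O=C(NC(=S)NNc1ncnc2ccccc12)c1cccc(Cl)c1`, built on a different core and carrying a 3-chlorophenyl on the carbonyl carbon, gives 4740 nM. Its number is the highest of the three, but its nearest neighbour compound 1 and its furthest neighbour compound 3 both sit within the scatter of it, so no order among the three can be drawn from these numbers.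

Compound 4 `Cc1ccccc1C(=O)NC(=S)NNc1ncnc2ccccc12` differs from compound 2 in one place: 2-methylphenyl in place of 3-chlorophenyl on a carbonyl carbon. Among the compounds with values here, the only measured step that bears on this change is the exchange of one fluorophenyl for another on the same carbonyl carbon, a 1.1-fold lower number from compound 1 to compound 3 (0.05 log units; within the scatter), which stayed within the scatter. On that single precedent a further change of the aryl group on the carbonyl carbon is expected to produce no step beyond the scatter in this assay, and the step of a 1.1-fold lower number from compound 2 to compound 4 (0.02 log units; within the scatter) is expected to be small. Compound 4 is therefore estimated at 4500 nM, with a range from 2000 nM to 10000 nM.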

Compound 4, half-maximal inhibitory concentration: 2770 nM
The estimate for compound 4 lay 1.6-fold (0.21 log units) above the measured number; low and high end bracket the measured number.
By their numbers in this assay, from the lowest: compounds 4, 3, 1 and 2 (each within the scatter of the next).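

In this assay, within the data shown here, the exchange of 3-chlorophenyl for 2-methylphenyl on a carbonyl carbon whose other neighbour is the amide-type nitrogen gives a 1.7-fold lower number from compound 2 to compound 4 (0.23 log units; within the scatter) and is the only step read so far on this core. The earlier fluorophenyl exchange sat on the core of compound 1 and kept the halogen, whereas here a chlorine-bearing aryl group gives way to an all-carbon one, and the step still stays within the scatter, so this place now has one such exchange read on each of the two cores. No measurement at hand accounts for the step or ties it to any property of either group.

Whether the same exchange behaves alike on the core of compound 1 remains open, and the two cores cannot be set against each other, since no pair shown differs in the core alone. Also open, from the compounds shown here alone, is whether a phenyl ring carrying an amine or a carboxylic acid, or a longer alkyl chain in place of the phenyl ring, would give a step beyond the scatter at this carbonyl carbon.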